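The source may hold more compounds than are shown below. What is called first, only, known or untested is meant among the compounds shown, and "the series" means these compounds.

Measured in an ADME assay for protein binding, using equilibrium dialysis, at pH 7.4, tested at 2 uM; on this read-out higher numbers stand for a larger free fraction and lower numbers for a smaller free fraction:
compound 1 `CON=C1CCC(N(c2cc(C#CC(C)(C)C)sc2C(=O)O)C(=O)[C@H]2CC[C@H](C)CC2)CC1` — 0.07
compound 2 `CC(C)N(C(=O)[C@H]1CC[C@@H]2C[C@@H]2CC1)c1cc(C#CC(C)(C)C)sc1C(=O)O` — 0.08
compound 3 `CC(C)(C)C#Cc1cc(N(C(=O)[C@H]2CC[C@H](C)CC2)[C@H]2CC[C@H](Oc3cccnc3)CC2)c(C(=O)O)s1` — 0.03

Compound 2 gives the highest of the three numbers in this assay. Compound 1 lies nearest, and the two sit within the usual scatter, so no order can be read between compound 1 and compound 2. Compound 3 lies furthest away, and its gap to compound 2 is beyond the scatter, so compound 2 shows the larger free fraction of these two.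

Compound 4 `CC(C)N(C(=O)[C@H]1[C@@H]2CCCC[C@@H]21)c1cc(C#CC(C)(C)C)sc1C(=O)O` has not been measured in this assay. It differs from compound 2 in one place: a group of 7 heavy atoms (7 carbon; one three-membered non-aromatic ring of carbon only, one six-membered non-aromatic ring of carbon only) in place of a group of 8 heavy atoms (8 carbon; one three-membered non-aromatic ring of carbon only, one seven-membered non-aromatic ring of carbon only), on a carbonyl carbon. Both groups carry a three-membered non-aromatic ring of carbon only; the exchange concerns the other ring, six-membered in compound 4 against seven-membered in compound 2.

Going by the values given here, no step between measured compounds covers this exchange, so no measured analogy is available. An exchange of this kind on a carbonyl carbon is expected to move the number in this assay only a little, most likely within the scatter; if any direction, a slightly higher number is expected. The expected step of a 1.3-fold higher number from compound 2 to compound 4 (0.10 log units; within the scatter) is therefore small. Compound 4 is estimated at 0.1, with a range from 0.05 to 0.2.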

Compound 4, unbound fraction: 0.04
Beside the measured number, compound 4's estimate is 2.5-fold (0.40 log units) above it; the measured number lies below the stated range.
By their numbers in this assay, from the lowest: compounds 3, 4, 1 and 2 (each within the scatter of the next, the first and the last beyond it).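

Going by these compounds alone, this is the first step that isolates the group on a carbonyl carbon whose other neighbour is the amide-type nitrogen, as the earlier compounds differ from one another in more than one place. With the three-membered ring kept, a six-membered non-aromatic ring of carbon in place of a seven-membered one gives a 2.0-fold lower number from compound 2 to compound 4 (0.30 log units; within the scatter) in this assay, so this single exchange does not separate the two compounds and no order can be read between them. There is no evidence to hand that bears on this result, and one pair does not establish a trend for ring size at this position.

Still open is whether the same exchange gives a comparable step when the amide-type nitrogen carries the other substituents seen in compound 1 and compound 3, since the shown compounds hold no such pair. Also open, on these data alone, is how far the free fraction in this assay responds at this carbonyl carbon to a group carrying a hydroxyl or an amine, as every group compared here consists of carbon only.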